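This account rests on a few compounds, and the source may have more. Where it says the series, first, only, none or still open, it means among the compounds named here.

Measured so far in a functional assay on MDA-MB-231 cells (Homo sapiens) for inhibition, read by sulforhodamine B assay, with a stated time of 48 h; on this read-out lower numbers stand for stronger inhibition and higher numbers for weaker inhibition:
- compound 1 `COc1ccc(C(O)(Cc2ccc(C)cc2)c2cccc3ccccc23)c(OC)c1OC`: > 20000 nM
- compound 2 `COc1ccc(C(c2ccc(OCCO)cc2)c2cccc3ccccc23)c(OC)c1OC`: > 20000 nM
- compound 3 `COc1ccc(/C(=N/OCC(=O)O)c2cccc3ccccc23)c(OC)c1OC`: > 20000 nM

Each entry is a limit of the assay and not a number. For the measured compounds named here, the series so far shows (the limit of > 20000 nM in this assay, at which 3 of the 3 values shown sit).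

Compound 2 therefore has no numerical position, and its reading of > 20000 nM is a limit only. The next analogue is compound 4 `COc1ccc(C(c2ccc(O)cc2)c2cccc3ccccc23)c(OC)c1OC`. The change from compound 2 is hydrogen in place of 2-hydroxyethyl on an oxygen on an aromatic ring, so that 4-(2-hydroxyethoxy)phenyl becomes 4-hydroxyphenyl.

Going by the values given here, no measured step gives a size for this change. In this assay, a small move toward stronger inhibition is expected, and a result no different from the limit would be equally unsurprising. The expected change is an at least 1.3-fold lower number from compound 2 to compound 4 (0.12 log units; that floor lies within the scatter). For compound 4 the estimated value is 15000 nM, with an expected range of 4000 nM to 30000 nM.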

Compound 4, half-maximal inhibitory concentration: 17400 nM
For compound 4 the middle estimate is 1.2-fold (0.06 log units) below the measured one; the measured number falls inside the stated range.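

In this assay, for the compounds shown here, hydrogen in place of 2-hydroxyethyl on an oxygen on an aromatic ring gives an at least 1.1-fold lower number from compound 2 to compound 4 (0.06 log units; that floor lies within the scatter), so 4-hydroxyphenyl is the first group to yield a number and not a limit. Compound 2 reads > 20000 nM, which is a limit and not a number. The step is therefore only a floor that lies within the scatter, and the true size of the change stays unknown, with most of the series still giving no number: the limit of > 20000 nM in this assay, at which 3 of the 4 values shown sit.

Open, going by these compounds, is whether the free hydroxy on this ring is needed for a measurable reading, or whether a methoxy, an amine or a longer chain ending in a carboxylic acid at this place would serve as well. Also open, on these data alone, is how far any such group would carry the reading from the limit.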